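Removing a Methyl Group from a Fused Ring

The source may hold more compounds than are shown below. What is called first, only, known or untested is meant among the compounds shown, and "the series" means these compounds.

Compound 2 `CCn1c(=O)/c(=C2\Sc3ccc(C)cc3N2C)s/c1=C\c1ccncc1Nc1ccccc1Cl` was tested in a functional assay on PC-3 cells (Homo sapiens) for inhibition (on this read-out higher numbers stand for weaker inhibition and lower numbers for stronger inhibition), where compound 2 gives 500 nM. Compound 1 `CCn1c(=O)/c(=C2\Sc3ccccc3N2C)s/c1=C\c1ccncc1Nc1ccccc1F` gives 360 nM in this assay, and the two values lie within the usual scatter of each other, so neither can be called stronger. Compound 3 `CCn1c(=O)/c(=C2\Sc3ccccc3N2C)s/c1=C\c1ccncc1Nc1ccccc1Cl` has not yet been measured; it differs from compound 2 by hydrogen in place of methyl on an aromatic carbon. For the measured compounds named here, no measured pair shows this change on its own, so the expected step is a 1.2-fold lower number from compound 2 to compound 3 (0.08 log units; within the scatter), which stays inside the scatter in either direction. Compound 3 is estimated at 420 nM, with a range from 200 nM to 900 nM.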

Compound 3, half-maximal inhibitory concentration: 780 nM
Beside the measured number, compound 3's estimate is 1.9-fold (0.27 log units) below it; measured number inside the range.
By their numbers in this assay, from the lowest: compounds 1, 2 and 3 (each within the scatter of the next, the first and the last beyond it).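

Replacing the methyl on this aromatic carbon with hydrogen gives a 1.6-fold higher number from compound 2 to compound 3 (0.19 log units; within the scatter) in this assay, so the methyl can go without a change that stands clear of repeat measurements. Compound 3 also allows a single-place comparison at the other changed site, where chloro in place of fluoro on an aromatic carbon gives a 2.2-fold higher number from compound 1 to compound 3 (0.34 log units; beyond the scatter), a modest weakening. Nothing available explains either step. Still open, on these data alone, is how an ethyl or methoxy group would read at the methyl position, and how a bromo group or a nitrile would read at the chloro position.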